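The compounds below may be only part of what the source reports. "The series", "measured", "known", "first", "only" and "open" are said of these compounds alone.

Working notes on the series. Compound 1 `CC1=CC[C@H](C(C)(C)NC(=S)NN)CC1` carries the shared core with a free terminal hydrazine; in a functional assay on NCI/ADR-RES cells (Homo sapiens) for inhibition, read by sulforhodamine B assay, with a stated time of 48 h (on this read-out lower numbers stand for stronger inhibition of growth and higher numbers for weaker inhibition of growth), compound 1 gives 39300 nM. Compound 2 `COc1ccc(/C=N/NC(=S)NC(C)(C)[C@H]2CC=C(C)CC2)cc1` bears a 4-methoxyphenyl on the carbon double-bonded to nitrogen, and in this assay compound 2 gives 43800 nM, the higher of the two plain numbers in hand, though its gap to compound 1 lies within the scatter, so no order between them can be read. Compound 3 `CC1=CC[C@H](C(C)(C)NC(=S)N/N=C/c2ccc(N(C)C)cc2)CC1` is reported in this assay only as a limit, > 100000 nM, not a number. Within the data shown here, the change dimethylamino in place of methoxy on an aromatic carbon gives an at least 2.2-fold higher number from compound 2 to compound 3 (0.35 log units; beyond the scatter), the only measured step on this aryl group, and its size is known only as a floor because of the limit of > 100000 nM in this assay, at which 1 of the 3 values shown sits. Compound 4 `CC1=CC[C@H](C(C)(C)NC(=S)N/N=C/c2ccccc2Cl)CC1` is not yet measured; it differs from compound 2 by 2-chlorophenyl in place of 4-methoxyphenyl on a carbon with a double bond to nitrogen. Among the measured compounds shown here, no measured step exchanges this aryl for a halogenated one, and the single step in hand at that position shows only a weakening. For compound 4 the expected step is a 1.0-fold higher number from compound 2 to compound 4 (0.01 log units; within the scatter), nothing beyond the scatter. Compound 4 is therefore estimated in this assay at 45000 nM, within 15000 nM to 130000 nM.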

Compound 4, concentration for 50% growth inhibition: 75000 nM
Compound 4: middle estimate off by 1.7-fold (0.22 log units), on the low side, within the range that was stated.
By their numbers in this assay, from the lowest: compounds 1, 2 and 4 (each within the scatter of the next). At a limit, above all of these: compound 3.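

In this assay, 2-chlorophenyl in place of 4-methoxyphenyl on a carbon with a double bond to nitrogen gives a 1.7-fold higher number from compound 2 to compound 4 (0.23 log units; within the scatter), so exchanging an aryl group that holds a hydrogen-bond acceptor for a chlorinated one that holds none produces no readable change. Among these compounds, this is the first step at this position with a plain number at both ends, and it shows that not every exchange on this aryl group moves the read-out beyond the scatter. The dimethylamino step from the earlier compounds remains known only as a floor: the limit of > 100000 nM in this assay, at which 1 of the 4 values shown sits.

The compounds shown leave open how an unsubstituted phenyl, or a fluorine or a carboxylic acid on the aryl group, would read at this position. Also open, as far as these compounds go, is the effect of a longer chain on the shared core.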